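From Cyclopropyl to Benzyl: One Change to Compound 1

The compounds below may be only part of what the source reports. "The series", "measured", "known", "first", "only" and "open" are said of these compounds alone.

Within the data shown here, in a functional assay on MGC-803 cells (Homo sapiens) for inhibition, read by MTT assay, with a stated time of 72 h (a lower number here means a stronger inhibitor, a higher number a weaker inhibitor), compound 1 (`Cc1cc(N2CC[C@@H](C)[C@@H](N(C)c3ncnc4[nH]ccc34)C2)n2nc(SCC3CC3)nc2n1`) gives 9540 nM and holds the lowest of the three numbers so far. Compound 2 (`C[C@@H]1CCN(c2cc(-c3ccccc3)nc3ncnn23)C[C@@H]1N(C)c1ncnc2[nH]ccc12`) gives 84900 nM and compound 3 (`Cc1nc2nc(SCc3ccc(Cl)cc3)nn2c(N2CC[C@@H](C)[C@@H](N(C)c3ncnc4[nH]ccc34)C2)c1C`) gives 90500 nM and both sit higher than compound 1, beyond the usual scatter. Compound 4 (`Cc1cc(N2CC[C@@H](C)[C@@H](N(C)c3ncnc4[nH]ccc34)C2)n2nc(SCCc3ccccc3)nc2n1`) is still unmeasured. It differs from compound 1 in one place, with benzyl in place of cyclopropyl on a saturated chain carbon bound to a sulfur. Among the measured compounds shown here, no measured pair shows this change alone. Compound 3, at 90500 nM and also carrying an aromatic ring on its sulfur chain, is the only hint, so a moderate rise toward weaker inhibition, beyond the scatter, is expected in this assay here. The expected change is a 3.1-fold higher number from compound 1 to compound 4 (0.50 log units; beyond the scatter) in size. For compound 4 the estimated value is 30000 nM (9000 nM to 90000 nM).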

Compound 4, half-maximal inhibitory concentration: 6190 nM
Beside the measured number, compound 4's estimate is 4.8-fold (0.69 log units) above it; measured number below the stated range.
By their numbers in this assay, from the lowest: compounds 4 and 1 (each within the scatter of the next); then compounds 2 and 3 (each within the scatter of the next).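

In this assay, placing benzyl in place of cyclopropyl on a saturated chain carbon bound to a sulfur gives a 1.5-fold lower number from compound 1 to compound 4 (0.19 log units; within the scatter). This position therefore takes a six-membered aromatic ring in place of a three-membered non-aromatic ring, with more heavy atoms, and the number stays level with that of compound 1.

On these data alone, whether an amine or a carboxylic acid at the end of this sulfur chain would leave the number just as level remains open. No measurement shown here offers a reason for this result.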